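Chromene carboxylates: aryl substituent change at the isoxazole

The source may report more compounds than this note shows. Statements on the series, on what has been measured and on what is new or still open speak of the compounds shown alone.

Measured in a functional assay on DU-145 cells (Homo sapiens) for inhibition, read by MTT assay, with a stated time of 24 h; on this read-out lower numbers stand for stronger inhibition and higher numbers for weaker inhibition:
compound 1 `O=C(O)C1=Cc2ccccc2OC1(OCc1cc(-c2ccc(F)cc2)no1)C(F)(F)F`: 168000 nM
compound 2 `CCOC(=O)C1=Cc2ccccc2OC1(OCc1cc(-c2ccc(Br)cc2)no1)C(F)(F)F`: 71700 nM
compound 3 `CCCCCCCCn1cc(COC2(C(F)(F)F)Oc3ccccc3C=C2C(=O)OCC)nn1`: > 150000 nM

Compound 1 gives the higher of the two numbers recorded; compound 2 sits lower, and the gap between them is beyond the usual scatter. For compound 3 the read-out is only a limit, > 150000 nM. Compound 4 `COc1ccc(-c2cc(COC3(C(F)(F)F)Oc4ccccc4C=C3C(=O)O)on2)cc1` is not yet measured. It differs from compound 1 in one place: methoxy in place of fluoro on an aromatic carbon. Among the measured compounds shown here, no step between measured compounds covers this change, so the expectation rests on compound 1 alone, which gives 168000 nM. The expected step is a 1.1-fold lower number from compound 1 to compound 4 (0.05 log units; within the scatter), none beyond the scatter. Compound 4 is estimated at 150000 nM, between 60000 nM and 400000 nM.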

Compound 4, half-maximal inhibitory concentration: 42000 nM
Compound 4: the middle estimate sits 3.6-fold (0.55 log units) above what was measured, and the stated range ends above it.
By their numbers in this assay, from the lowest: compounds 4 and 2 (each within the scatter of the next); then compound 1.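

Among the compounds shown here, replacing 4-fluorophenyl with 4-methoxyphenyl gives the first single-place comparison, a 4.0-fold lower number from compound 1 to compound 4 (0.60 log units; beyond the scatter), so this aromatic carbon, para to a large group, is not silent in this assay. The step is modest and rests on a single pair, both members keeping the carboxylic acid. Compound 3 stands only as a limit of the read-out: the limit of > 150000 nM in this assay, at which 1 of the 4 values shown sits.

On these data alone, whether an amine or a longer ether chain such as ethoxy at this position would extend the step remains open. Also open, as far as these compounds go, is whether the same change carries over to the ethyl esters.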